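A few compounds are considered here, and "the series" means these few. Any claim that something is new, unique, unknown or untested is made for them only; others in the source may bear on it.

The measured compounds:

compound 1 `Oc1cccc(-c2cc(-c3ccc(F)cc3)cc(-c3ccccc3O)n2)c1`: in a functional assay on T47D cells (Homo sapiens) for inhibition (a higher number here means a weaker inhibitor, a lower number a stronger inhibitor), compound 1 gives > 50000 nM, which is a limit of the assay and not a number.
compound 2 `Oc1ccc(-c2cc(-c3ccc(F)cc3)cc(-c3ccccc3O)n2)cc1`: in this assay compound 2 gives > 50000 nM, again a limit rather than a number.
compound 3 `Oc1cccc(-c2cc(-c3ccccc3F)cc(-c3cccc(O)c3)n2)c1`: in this assay compound 3 gives 4370 nM.

Two of the three values thus sit at the limit of > 50000 nM in this assay, at which 2 of the 3 values shown sit, and only compound 3 yields a readable number. The change from compound 1 to compound 2 is 4-hydroxyphenyl in place of 3-hydroxyphenyl on an aromatic carbon. Its step, a step that the two limits leave unreadable from compound 1 to compound 2, cannot be sized, since both ends are limits. How the core of compound 1 differs from the core of compound 3 is not broken down here.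

Compound 4 `Oc1ccc(-c2cc(-c3ccccc3F)cc(-c3cccc(O)c3)n2)cc1` has not been measured. It differs from compound 3 by 4-hydroxyphenyl in place of 3-hydroxyphenyl on an aromatic carbon. This is the same kind of change as from compound 1 to compound 2, but not the same: there the place was meta to a 2-hydroxyphenyl group and meta to a 4-fluorophenyl group, here it is meta to a 2-fluorophenyl group and meta to a 3-hydroxyphenyl group. The earlier step is unreadable. The expectation therefore rests on compound 3 alone, at 4370 nM. The step from compound 3 to compound 4 in this assay is expected to be a modest weakening, a 2.1-fold higher number from compound 3 to compound 4 (0.31 log units; beyond the scatter). Compound 4 is estimated at 9000 nM, most likely between 2500 nM and 35000 nM.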

Compound 4, half-maximal inhibitory concentration: 6370 nM
The estimate for compound 4 lay 1.4-fold (0.15 log units) above the measured number; the measured number falls inside the stated range.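

In this assay, swapping 3-hydroxyphenyl for 4-hydroxyphenyl on the core of compound 3 gives a 1.5-fold higher number from compound 3 to compound 4 (0.16 log units; within the scatter), so on this core the assay does not tell the two groups apart. The same swap on the core of compound 1 cannot be read, since both of its values are limits of the assay and not numbers: the limit of > 50000 nM in this assay, at which 2 of the 4 values shown sit. The result therefore describes one core only; it does not show that the change carries over from one core to the other, nor that it fails to, as there is just one readable step and nothing to set beside it.

The compounds shown leave open which of the differences between the two cores matters, as none of them changes those differences one at a time. As far as these compounds go, it also remains open how an amine or a carboxylic acid would read in this assay in place of the hydroxyl group on the 4-hydroxyphenyl ring of compound 4.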